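Swapping the sulfonyl arm of an indole acrylonitrile for benzoyl

The source may report more compounds than this note shows. Statements on the series, on what has been measured and on what is new or still open speak of the compounds shown alone.

Measured compounds:
compound 1 `O=C(/C(=C\c1c(-c2ccccc2)[nH]c2ccccc12)S(=O)(=O)c1ccccc1)c1ccccc1`: 4900 nM
compound 2 `N#C/C(=C\c1c(-c2ccccc2)[nH]c2ccccc12)S(=O)(=O)c1ccccc1`: 2000 nM

In a functional assay on HCT-116 cells (Homo sapiens) for inhibition, read by sulforhodamine B assay, with a stated time of 48 h (a higher number here means a weaker inhibitor of growth, a lower number a stronger inhibitor of growth), compound 2 gives the lower of the two numbers; compound 1 sits higher by a 2.5-fold lower number from compound 1 to compound 2 (0.39 log units; beyond the scatter), a step that exchanged the group on the other chain carbon. Compound 3 `N#C/C(=C\c1c(-c2ccccc2)[nH]c2ccccc12)C(=O)c1ccccc1` is not yet measured and carries a different change: benzoyl in place of phenylsulfonyl on a double-bonded chain carbon bound to a double-bonded chain carbon and a triple-bonded carbon. Among the compounds with values here, no measured step touches the phenylsulfonyl group, so the direction of a 1.3-fold higher number from compound 2 to compound 3 (0.10 log units; within the scatter) is uncertain and is expected to stay small. Compound 3 is therefore estimated at 2500 nM in this assay, within 800 nM to 8000 nM.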

Compound 3, concentration for 50% growth inhibition: 5300 nM
The estimate for compound 3 lay 2.1-fold (0.33 log units) below the measured number; the range from low to high includes it.
By their numbers in this assay, from the lowest: compound 2; then compounds 1 and 3 (each within the scatter of the next).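

In this assay, phenylsulfonyl and benzoyl are not interchangeable on this chain carbon when the nitrile stays in place: the change gives a 2.7-fold higher number from compound 2 to compound 3 (0.42 log units; beyond the scatter). Together with a 2.5-fold lower number from compound 1 to compound 2 (0.39 log units; beyond the scatter), this means that replacing either group of compound 2 raises the number beyond the scatter, so its pairing of nitrile and phenylsulfonyl gives the strongest growth inhibition of the three. No measurement here explains why this swap changes the number. Going by these compounds, it remains open whether an amide or a carboxylic acid in place of phenylsulfonyl would match compound 2.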